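The source may report more compounds than this note shows. Statements on the series, on what has been measured and on what is new or still open speak of the compounds shown alone.

Three compounds share one core and differ only in the group on one aromatic carbon. Compound 1 `O=C(NO)[C@H]1CCCCN1S(=O)(=O)N1CC=C(c2ccc(F)cc2)CC1` carries a fluoro there; in a functional assay on MONO-MAC-6 cells (Homo sapiens) for inhibition (a higher number here means a weaker inhibitor, a lower number a stronger inhibitor), compound 1 gives 300 nM. Compound 2 `O=C(NO)[C@H]1CCCCN1S(=O)(=O)N1CC=C(c2ccc(-c3ccccc3)cc2)CC1` carries a phenyl and in this assay compound 2 gives 19000 nM, while compound 3 `O=C(NO)[C@H]1CCCCN1S(=O)(=O)N1CC=C(c2ccc(Oc3ccccc3)cc2)CC1` carries a phenoxy and in this assay compound 3 gives 3300 nM. Compound 3 therefore sits second highest of the three numbers: an 11-fold higher number from compound 1 to compound 3 (1.04 log units; beyond the scatter), and a 5.8-fold lower number from compound 2 to compound 3 (0.76 log units; beyond the scatter).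

The new compound 4 `CCCc1ccc(C2=CCN(S(=O)(=O)N3CCCC[C@@H]3C(=O)NO)CC2)cc1` changes this same position once more: propyl in place of phenoxy on an aromatic carbon. Two kinds of measured step speak to it. Replacing fluoro with an aromatic group raised the number sharply, a 63-fold higher number from compound 1 to compound 2 (1.80 log units; beyond the scatter) and an 11-fold higher number from compound 1 to compound 3 (1.04 log units; beyond the scatter); the step between the two aromatic groups was smaller, a 5.8-fold lower number from compound 2 to compound 3 (0.76 log units; beyond the scatter). Propyl carries no ring, so compound 4 no longer bears the feature shared by compounds 2 and 3, yet it is not a fluoro either, so a full return to the number of compound 1 is not expected. The expected step in this assay is a lower number, a 2.2-fold lower number from compound 3 to compound 4 (0.34 log units; beyond the scatter), landing between compound 1 and compound 3. The estimate for compound 4 is 1500 nM, with a likely range from 400 nM to 5000 nM.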

Compound 4, half-maximal inhibitory concentration: 2600 nM
Estimate against measurement, compound 4: 1.7-fold (0.24 log units) below, and the stated range covers the measured number.
By their numbers in this assay, from the lowest: compound 1; then compounds 4 and 3 (each within the scatter of the next); then compound 2.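

In this assay, swapping phenoxy for propyl gives two compounds that cannot be told apart (a 1.3-fold lower number from compound 3 to compound 4 (0.10 log units; within the scatter)), even though propyl has no ring and the phenoxy has one. Moving away from fluoro also weakens inhibition when the new group is a plain chain (an 8.7-fold higher number from compound 1 to compound 4 (0.94 log units; beyond the scatter)), so this loss does not depend on an aromatic ring in the new group, and compound 1 remains the strongest inhibitor of the four. A ring does not settle the outcome either, as compound 2, with its phenyl, stands apart from the propyl compound (a 7.3-fold lower number from compound 2 to compound 4 (0.86 log units; beyond the scatter)) while the ring-bearing compound 3 does not, and nothing shown here explains these differences.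

From the compounds shown here alone, it remains open whether a shorter chain such as ethyl would bring the number back towards that of compound 1, or whether a longer chain such as hexyl would push it towards that of compound 2. The effect of an amine or a carboxylic acid at this same position on the shared core is also unknown.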